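The source may hold more compounds than are shown below. What is called first, only, known or untested is meant among the compounds shown, and "the series" means these compounds.

Compound 1 `O=C(Nc1cccc(-n2cc(-c3ccncc3)c(-c3ccc(Cl)c(O)c3)n2)c1)Nc1cccc(C(F)(F)F)c1`: 2470 nM
Compound 2 `COc1cc(-c2nn(-c3cccc(NC(=O)c4cccc(C(F)(F)F)c4)c3)cc2-c2ccncc2)ccc1Cl`: 2550 nM

In a functional assay on T47D cells (Homo sapiens) for inhibition, read by sulforhodamine B assay, with a stated time of 48 h (on this read-out lower numbers stand for stronger inhibition of growth and higher numbers for weaker inhibition of growth), compound 1 gives 2470 nM and stands level with compound 2 at 2550 nM, the two lying within the scatter of each other. Compound 3 `O=C(Nc1cccc(-n2cc(-c3ccncc3)c(-c3ccc(Cl)c(O)c3)n2)c1)Nc1ccc(Cl)c(Cl)c1` carries 3,4-dichlorophenyl in place of 3-(trifluoromethyl)phenyl on an amide-type nitrogen and is otherwise the same as compound 1. For the measured compounds named here, no measured pair shows this change, so the data give no size for it. The estimated 1.2-fold lower number from compound 1 to compound 3 (0.07 log units; within the scatter) is expected to stay within the scatter, with no firm direction. For compound 3 the expected value is 2100 nM, with an estimated range of 850 nM to 5200 nM around it.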

Compound 3, concentration for 50% growth inhibition: 1550 nM
Compound 3: middle estimate off by 1.4-fold (0.13 log units), on the high side, within the range that was stated.
By their numbers in this assay, from the lowest: compounds 3, 1 and 2 (each within the scatter of the next).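

On the amide-type nitrogen, 3,4-dichlorophenyl in place of 3-(trifluoromethyl)phenyl gives a 1.6-fold lower number from compound 1 to compound 3 (0.20 log units; within the scatter) in this assay. For the compounds shown here, this is the first single-place comparison, and it shows that this position accepts one substituted phenyl for the other without a change beyond the scatter. No evidence at hand bears on this result. The compounds shown leave open whether a plain phenyl, or a longer chain ending in an amine or a carboxylic acid, would hold the number at this nitrogen.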